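Loss of a methoxy group in two related pairs

A few compounds are considered here, and "the series" means these few. Any claim that something is new, unique, unknown or untested is made for them only; others in the source may bear on it.

Compound 1 `COc1ccc2[nH]cc(/C=C(\C#N)C(=O)c3c[nH]c4ccccc34)c2c1` and compound 2 `N#C/C(=C\c1c[nH]c2ccccc12)C(=O)c1c[nH]c2ccccc12` were both tested in a functional assay on PC-3 cells (Homo sapiens) for cytotoxicity, read by WST assay, with a stated time of 24 h; a lower number here means a stronger inhibitor, a higher number a weaker inhibitor. Compound 1 gives 33200 nM. For compound 2 the assay reports only a limit, > 50000 nM. The measured step of an at least 1.5-fold higher number from compound 1 to compound 2 (0.17 log units; that floor lies within the scatter) goes with the change (hydrogen in place of methoxy on an aromatic carbon). Compound 3 `COc1ccc2c(C(=O)/C(C#N)=C/c3cn(Cc4ccc(Cl)cc4)c4ccccc34)c[nH]c2c1` rests on a different core; how its core differs from that of compound 1 is not broken down here. For compound 3 the assay again reports only a limit, > 50000 nM. Compound 4 `N#C/C(=C\c1cn(Cc2ccc(Cl)cc2)c2ccccc12)C(=O)c1c[nH]c2ccccc12` differs from compound 3 by hydrogen in place of methoxy on an aromatic carbon, the same change as from compound 1 to compound 2. The expected step is a step that the limit leaves unreadable from compound 3 to compound 4. That expectation rests on compound 3, which already sits at the limit of > 50000 nM in this assay, at which 2 of the 3 values shown sit, and on the step of an at least 1.5-fold higher number from compound 1 to compound 2 (0.17 log units; that floor lies within the scatter). Compound 4 is therefore estimated at 90000 nM in this assay, with a likely range from 40000 nM to 250000 nM.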

Compound 4, half-maximal inhibitory concentration: > 50000 nM
Compound 4 gave a limit, no number (the forecaster's own chance of this, stated with the estimate: 85%); the middle value is on the limit's open side.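

Neither the step from compound 3 to compound 4 nor the step from compound 2 to compound 4 can be read, because all three compounds sit at a limit of the assay: the limit of > 50000 nM in this assay, at which 3 of the 4 values shown sit.

The compounds shown leave open how far, if at all, methoxy or 4-chlorobenzyl shifts the read-out at this end of the scale.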